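Phenyl for ethyl on the side chain ether

This account rests on a few compounds, and the source may have more. Where it says the series, first, only, none or still open, it means among the compounds named here.

In an ADME assay on RAW264.7 cells (Mus musculus) for cytotoxicity, read by MTT assay, with a stated time of 24 h, in the presence of a further agent that is not named here (on this read-out higher numbers stand for weaker inhibition and lower numbers for stronger inhibition), compound 1 `COCCCCOc1ccc(C(O)C2OC(=O)c3c(OC)cc(OC)cc32)cc1` gives > 40000 nM, which is a limit of the assay and not a number. Compound 2 `CCOCCOc1ccc(C(O)C2OC(=O)c3c(OC)cc(OC)cc32)cc1` gives > 40000 nM, likewise a limit and not a number. This leaves compound 2 with no exact value, and the evidence so far amounts to the limit of > 40000 nM in this assay, at which 2 of the 2 values shown sit. Among the measured compounds shown here, the only measured step is a step that the two limits leave unreadable from compound 1 to compound 2, so it offers no size to carry forward.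

Compound 3 `COc1cc(OC)c2c(c1)C(C(O)c1ccc(OCCOc3ccccc3)cc1)OC2=O` differs from compound 2 by phenyl in place of ethyl on an oxygen on a saturated carbon. The change is phenyl in place of ethyl on an oxygen on a saturated carbon, which turns 2-ethoxyethyl into 2-phenoxyethyl. For the measured compounds named here, no measured step covers this exchange. The expectation therefore rests on compound 2, whose > 40000 nM is a limit, and no direction can be read from the data. In this assay the expected move is a number no higher from compound 2 to compound 3 (the limit leaves the size open), with no change beyond the scatter anticipated. For compound 3 the estimate is 40000 nM, with an expected range from 15000 nM to 80000 nM, and another report as a limit is considered likely.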

Compound 3, half-maximal inhibitory concentration: > 40000 nM
Compound 3 ended at the assay's limit; the forecaster's own chance of this, stated with the estimate: 70%; the middle value lies on the limit itself.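

In this assay compound 3 gives > 40000 nM, a limit of the assay and not a number. No new step can be read among compound 1, compound 2 and compound 3, which all stand at the same limit: the limit of > 40000 nM in this assay, at which 3 of the 3 values shown sit.

What stays open is the exact value of each of these compounds, and whether their side chains differ at all on this read-out.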